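The compounds below may be only part of what the source reports. "The series", "measured", "known", "first", "only" and "open" are said of these compounds alone.

Compounds measured so far, all in the same binding test:

compound 1 `CC[C@@H](Nc1c(Nc2cccc(C(=O)N(C)C)c2O)c(=O)c1=O)c1cc(C)cs1` — 24 nM
compound 2 `CCc1coc([C@@H](CC)Nc2c(Nc3cccc(C(=O)N(C)C)c3O)c(=O)c2=O)c1` — 7 nM
compound 3 `CC[C@@H](Nc1c(Nc2cccc(C(=O)N(C)C)c2O)c(=O)c1=O)c1cc(C(C)C)co1` — 3 nM

The numbers come from an assay on CHO cells for displacement of a labelled ligand from C-X-C chemokine receptor type 1 (Homo sapiens) (a higher number here means a weaker inhibitor, a lower number a stronger inhibitor), and compound 3 gives the lowest of the three. Its lead over its nearest neighbour is a 2.3-fold lower number from compound 2 to compound 3 (0.37 log units; beyond the scatter), and over the furthest it is an 8.0-fold lower number from compound 1 to compound 3 (0.90 log units; beyond the scatter). All three share the same core and the same ethyl-bearing chain carbon; they differ only in the ring at the end of that chain and in what sits on it.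

Compound 4 `CC[C@@H](Nc1c(Nc2cccc(C(=O)N(C)C)c2O)c(=O)c1=O)c1cc(C(C)(C)C)co1` takes one more step along the same line: methyl in place of hydrogen on a saturated chain carbon bound to an aromatic carbon and two saturated chain carbons. The most direct precedent is the change from compound 2 to compound 3, in which the side group on the furan ring also grew by a single carbon and the result was a 2.3-fold lower number from compound 2 to compound 3 (0.37 log units; beyond the scatter). The step from compound 1 to compound 3 points the same way but mixes in the ring swap, so it bears less directly. On that basis a further small decrease is expected, though a growing side group need not keep paying off, so a smaller gain than before, or none beyond the scatter, is the likelier outcome. The expected step is a 1.4-fold lower number from compound 3 to compound 4 (0.13 log units; within the scatter), and compound 4 is estimated at 2.2 nM, with a range from 0.8 nM to 6 nM.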

Compound 4, inhibition constant: 10 nM
The estimate for compound 4 lay 4.5-fold (0.66 log units) below the measured number, outside the stated range (above it).
By their numbers in this assay, from the lowest: compound 3; then compounds 2 and 4 (each within the scatter of the next); then compound 1.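

In this assay the gain from enlarging the side group on the furan ring does not continue: going from isopropyl to tert-butyl gives a 3.3-fold higher number from compound 3 to compound 4 (0.52 log units; beyond the scatter) and so undoes the benefit seen with the previous added carbon, which makes isopropyl the best of the three side groups on furan. Ethyl and tert-butyl cannot be separated, with a 1.4-fold higher number from compound 2 to compound 4 (0.15 log units; within the scatter) lying inside the usual scatter, while the 4-(tert-butyl)furan-2-yl group still compares well with the 4-methylthiophen-2-yl group of compound 1, giving a 2.4-fold lower number from compound 1 to compound 4 (0.38 log units; beyond the scatter) in a step that changes both ring and side group. Nothing measured here explains this reversal.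

From the compounds shown here alone, it remains open whether cyclopropyl or a straight propyl chain would match isopropyl at this place. Going by these compounds, it is also open whether isopropyl would give the same benefit on the thiophene ring.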